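A few compounds are considered here, and "the series" means these few. Any claim that something is new, unique, unknown or untested is made for them only; others in the source may bear on it.

Measured so far, in a functional assay (trachea) with Cavia porcellus as the target; a lower number here means that less compound is needed, a higher number that more compound is needed for the effect:
- compound 1 `CCCn1c(=O)n(CCC(=O)O)c(=O)c2[nH]cnc21` gives 21200 nM
- compound 2 `CCCn1c(=O)n(CCCN(C)C)c(=O)c2[nH]cnc21` gives 20500 nM
- compound 3 `CCCn1c(=O)n(CCCCC(C)=O)c(=O)c2[nH]cnc21` gives 60 nM

Compound 2 has the second highest of the three numbers. Its nearest neighbour is compound 1, whose number is within the scatter of it, so the two cannot be told apart: a 1.0-fold lower number from compound 1 to compound 2 (0.01 log units; within the scatter). Its furthest neighbour is compound 3, a long way off: a 340-fold lower number from compound 2 to compound 3 (2.53 log units; beyond the scatter).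

The next compound, compound 4 `CCCn1c(=O)n(C)c(=O)c2[nH]cnc21`, differs from compound 2 in one place: hydrogen in place of 2-(dimethylamino)ethyl on a saturated chain carbon bound to an aromatic nitrogen. Going by the values given here, none of the measured steps removes a chain in this way. The step from compound 1 to compound 2 swaps one chain end for another and stays within the scatter, while the step from compound 2 to compound 3, likewise a swap at the chain end, is large. Neither shows what happens when the chain is cut back to a hydrogen, so the expectation for compound 4 rests mainly on the two weak compounds sharing the core. On that basis compound 4 is expected to sit near compound 2, with a step of a 1.0-fold lower number from compound 2 to compound 4 (0.01 log units; within the scatter), well inside the scatter. The estimate for compound 4 is 20000 nM, within a range from 4000 nM to 100000 nM.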

Compound 4, half-maximal effective concentration: 1600 nM
Compound 4: middle estimate off by 13-fold (1.10 log units), on the high side; measured number outside the range, below it.
By their numbers in this assay, from the lowest: compound 3; then compound 4; then compounds 2 and 1 (each within the scatter of the next).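

In this assay, replacing the chain with hydrogen, which leaves only the methyl of compound 4, gives a clear gain over both chains ending in a charged-looking group's place of dimethylamino or carboxy: a 13-fold lower number from compound 2 to compound 4 (1.11 log units; beyond the scatter) and a 13-fold lower number from compound 1 to compound 4 (1.12 log units; beyond the scatter). So at this place, on a saturated chain carbon bound to an aromatic nitrogen, those two chains cost more than having no chain at all, yet a chain is not a penalty in itself, as a 27-fold higher number from compound 3 to compound 4 (1.43 log units; beyond the scatter) shows that compound 3, with its 3-acetylpropyl group, lies well beyond the bare methyl on the other side. The substituent here can therefore move the number in either direction, depending on which chain is attached, and nothing available explains this difference.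

As far as these compounds go, it remains open whether compound 3 owes its low number to the acetyl end or simply to the length of its chain, a question that a plain hexyl chain with no carbonyl could settle. Also open, from the compounds shown here alone, is how a chain of that same length ending in a hydroxyl group, or in a primary amine, would compare.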